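Methoxy for methyl on the aryl hydroxamic acid series

This account rests on a few compounds, and the source may have more. Where it says the series, first, only, none or still open, it means among the compounds named here.

Measured in a physicochemical assay for solubility, read by HPLC, in phosphate buffer, with a stated time of 24 h, at pH 7.4, tested at 100 uM (a lower number here means a less soluble compound, a higher number a more soluble compound), so far
- compound 1 `CC(CCCCC(=O)NO)Nc1c(Nc2ccccc2)c(=O)c1=O` gives 93000000 nM
- compound 2 `Cc1ccc(Nc2c(NC(C)CCCCC(=O)NO)c(=O)c2=O)cc1` gives 83000000 nM

Among the compounds with values here, compound 2 stands within the scatter of compound 1, the only other measured compound. Next is compound 3 `COc1ccc(Nc2c(NC(C)CCCCC(=O)NO)c(=O)c2=O)cc1`, with methoxy in place of methyl on an aromatic carbon, para to a large group: methoxy in place of methyl on an aromatic carbon. Within the data shown here, one measured step bears on this, also a change on an aromatic carbon: a 1.1-fold lower number from compound 1 to compound 2 (0.05 log units; within the scatter), within the scatter. No step beyond the scatter is therefore expected in this assay. The expected change is a 1.0-fold lower number from compound 2 to compound 3 (0.02 log units; within the scatter). For compound 3 the estimated value is 80000000 nM, with an expected range of 45000000 nM to 140000000 nM.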

Compound 3, solubility: 85000000 nM
For compound 3 the middle estimate is 1.1-fold (0.03 log units) below the measured one, and the stated range covers the measured number.
By their numbers in this assay, from the lowest: compounds 2, 3 and 1 (each within the scatter of the next).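

In this assay the change from 4-methylphenyl to 4-methoxyphenyl gives (a 1.0-fold higher number from compound 2 to compound 3 (0.01 log units; within the scatter)), so a hydrogen-bond acceptor can enter at this aromatic carbon, para to a large group, with the step staying within the scatter. Methoxy in place of hydrogen reads (a 1.1-fold lower number from compound 1 to compound 3 (0.04 log units; within the scatter)), which puts a second group at this position within the scatter of hydrogen. Nothing measured here gives a reason for this.

Going by these compounds, an amine or a carboxylic acid at this position remains open. So does a longer chain in place of methoxy.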